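The source may report more compounds than this note shows. Statements on the series, on what has been measured and on what is new or still open speak of the compounds shown alone.

In a functional assay on SMMC-7721 cells (Homo sapiens) for inhibition, read by CCK-8 assay, with a stated time of 72 h, tested at 8 uM (a lower number here means less inhibition of growth, a higher number more inhibition of growth at the concentration tested), compound 2 (`Cc1cc(C)cc(SCc2ccc(/C=C/C(=O)Nc3ccccc3N)cc2)c1`) gives 7.13% and stands lowest of the two compounds measured, under compound 1 (`COc1ccc(SCc2ccc(/C=C/C(=O)Nc3ccccc3N)cc2)cc1OC`) at 44.6% on the same read-out. Compound 3 (`Nc1ccccc1NC(=O)/C=C/c1ccc(CSc2ccc(Cl)cc2)cc1`) differs from compound 2 in one place, on a sulfur, where 4-chlorophenyl stands in place of 3,5-dimethylphenyl (4-chlorophenyl in place of 3,5-dimethylphenyl on a sulfur). Going by the values given here, only one measured step bears on this change: a number 37.5 percentage points lower from compound 1 to compound 2 (beyond the scatter) is large and beyond the scatter, and it came from a change on that same sulfur. Among the compounds with values here, no measured compound carries chlorine, so the direction is not fixed by the data. With compound 2 at 7.13% there is little room below, so a moderate rise in this assay is expected. The expected change is an estimated a number 17.9 percentage points higher from compound 2 to compound 3 (beyond the scatter). For compound 3 the estimated value is 25% (expected range 9% to 48%).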

Compound 3, percent growth inhibition at one concentration: 16.5%
The estimate for compound 3 lay 8.5 percentage points above the measured number; measured number inside the range.
By their numbers in this assay, from the lowest: compounds 2 and 3 (each within the scatter of the next); then compound 1.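

In this assay, the step of a number 9.4 percentage points higher from compound 2 to compound 3 (within the scatter) leaves 4-chlorophenyl and 3,5-dimethylphenyl on the sulfur indistinguishable at this position. The step of a number 28.1 percentage points lower from compound 1 to compound 3 (beyond the scatter) shows that the large gap seen earlier does not belong to 3,5-dimethylphenyl alone, since among these three compounds only the 3,4-dimethoxyphenyl group of compound 1 stands apart. No measurement given here accounts for that separation.

On these data alone, it remains open whether a single methoxy group on the phenyl ring, at either of the positions it holds in compound 1, would keep that level of growth inhibition. Also open, as far as these compounds go, is how an amine or a carboxylic acid on that ring would read, or a sulfone in place of the sulfur.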